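Chloro for Methyl on the Aryl Group of Compound 3

The compounds below may be only part of what the source reports. "The series", "measured", "known", "first", "only" and "open" are said of these compounds alone.

Three measured compounds share one core, and none of them reaches a number in a functional assay on SMMC-7721 cells (Homo sapiens) for cytotoxicity, read by MTT assay, with a stated time of 4 days; a higher number here means a weaker inhibitor, a lower number a stronger inhibitor. Compound 1 `C=C1C[C@]23C[C@@]1(O)CC[C@H]2c1ccc(OS(=O)(=O)c2ccc(C)cc2)c(C)c1[C@@H]3Cn1cc(-c2ccc(Br)cc2)nn1` gives only a limit of > 20000 nM. Compound 2 `COc1ccc(-c2cn(C[C@H]3c4c(ccc(O)c4C)[C@@H]4CC[C@@]5(C)C[C@]43CC5=O)nn2)cc1` also gives only a limit, > 20000 nM. Compound 3 `C=C1C[C@]23C[C@@]1(O)CC[C@H]2c1cc(Br)c(O)c(C)c1[C@@H]3Cn1cc(-c2ccc(C)cc2)nn1` likewise gives only a limit, > 20000 nM. Within the data shown here, compound 3 thus stands nowhere apart from the others: all three sit at the limit of > 20000 nM in this assay, at which 3 of the 3 values shown sit, so no measured step can be told. Compound 4 `C=C1C[C@]23C[C@@]1(O)CC[C@H]2c1cc(Br)c(O)c(C)c1[C@@H]3Cn1cc(-c2ccc(Cl)cc2)nn1` differs from compound 3 by chloro in place of methyl on an aromatic carbon. With every shown value a limit, no change beyond the scatter is expected in this assay , and the step that the limit leaves unreadable from compound 3 to compound 4 that is expected stays within it. Compound 4 is expected at 30000 nM, with a range from 15000 nM to 120000 nM, and most likely to be reported as a limit once more.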

Compound 4, half-maximal inhibitory concentration: 19100 nM
Compound 4: the middle estimate sits 1.6-fold (0.20 log units) above what was measured; the range from low to high includes it.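

Compound 4 is the only compound shown that returns a number rather than a limit in this assay, at 19100 nM. The change from 4-methylphenyl to 4-chlorophenyl comes with an at least 1.0-fold lower number from compound 3 to compound 4 (0.01 log units; that floor lies within the scatter), so no change beyond the scatter can be claimed for this position. For compound 3 the value > 20000 nM is a limit, and the true size of the step stays unknown: the limit of > 20000 nM in this assay, at which 3 of the 4 values shown sit.

Still open, going by these compounds, is how an amine or a carboxylic acid at this position would read in this assay on the same core.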